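Longer chain on a shared core: expected cytotoxicity

The source may report more compounds than this note shows. Statements on the series, on what has been measured and on what is new or still open speak of the compounds shown alone.

Three compounds with the same core were tested in a functional assay on MCF7 cells (Homo sapiens) for cytotoxicity, read by MTT assay; on this read-out lower numbers stand for stronger inhibition and higher numbers for weaker inhibition:

Compound 1, `CCCCCCCCCCCC(=O)Nc1cc2c(cc1F)c(=O)c(C(=O)OCC)cn2CC`, gave 11200 nM.
Compound 2, `CCCCCCCCCCCCCCCC(=O)Nc1cc2c(cc1F)c(=O)c(C(=O)OCC)cn2CC`, gave 18600 nM.
Compound 3, `CCCCCCCCCCCCCC(=O)Nc1cc2c(cc1F)c(=O)c(C(=O)OCC)cn2CC`, gave 9100 nM.

The three differ only in the length of the chain on the amide. The difference between compound 1 and compound 3 is ethyl in place of hydrogen on a saturated chain carbon, ten or more bonds along the chain from a carbonyl carbon; that step gave a 1.2-fold lower number from compound 1 to compound 3 (0.09 log units; within the scatter). The step from compound 2 to compound 3 gave a 2.0-fold lower number from compound 2 to compound 3 (0.31 log units; beyond the scatter), so compound 3 stands apart from compound 2 beyond the scatter, while compound 1 and compound 3 lie within the scatter of each other.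

The change from compound 1 to compound 2 is butyl in place of hydrogen on a saturated chain carbon, ten or more bonds along the chain from a carbonyl carbon, and it made a 1.7-fold higher number from compound 1 to compound 2 (0.22 log units; within the scatter). Compound 4, `CCCCCCCCCCCCCCCCCC(=O)Nc1cc2c(cc1F)c(=O)c(C(=O)OCC)cn2CC`, has not yet been measured in this assay. Going by the values given here, it differs from compound 3 by butyl in place of hydrogen on a saturated chain carbon, ten or more bonds along the chain from a carbonyl carbon, which is the same change as the one from compound 1 to compound 2, at the same place. Only that one earlier example of the change exists among these compounds, and its step lies within the scatter, so no trend beyond these compounds can be claimed.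

Compound 4 is expected to show a 1.6-fold higher number from compound 3 to compound 4 (0.22 log units; within the scatter), because the same change earlier gave a 1.7-fold higher number from compound 1 to compound 2 (0.22 log units; within the scatter). Compound 4 is estimated to give about 15000 nM in this assay, with a likely range from 6500 nM to 40000 nM.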

Compound 4, half-maximal inhibitory concentration in the MCF7 assay: 28400 nM
Compound 4: middle estimate off by 1.9-fold (0.28 log units), on the low side; the range from low to high includes it.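

In the MCF7 assay compound 3 gave 9100 nM and compound 4 gave 28400 nM; butyl in place of hydrogen gave a 3.1-fold higher number from compound 3 to compound 4 (0.49 log units; beyond the scatter), and this step does not differ from the earlier butyl step by more than the scatter of two such steps: the same change on two cores in the MCF7 assay, a 1.7-fold higher number (0.22 log units; within the scatter) from compound 1 to compound 2 and a 3.1-fold higher number (0.49 log units; beyond the scatter) from compound 3 to compound 4, 1.9-fold (0.27 log units) apart, within the scatter of two such steps. Ethyl in place of hydrogen, which in the MCF7 assay gave a 1.5-fold higher number from compound 2 to compound 4 (0.18 log units; within the scatter), likewise carries across the two chains without a difference beyond that scatter: the same change on two cores in the MCF7 assay, a 1.2-fold lower number (0.09 log units; within the scatter) from compound 1 to compound 3 and a 1.5-fold higher number (0.18 log units; within the scatter) from compound 2 to compound 4, 1.9-fold (0.27 log units) apart, within the scatter of two such steps. Going by these compounds alone, in the MCF7 assay the hexyl change, a 2.5-fold higher number from compound 1 to compound 4 (0.40 log units; beyond the scatter), has no second example to set beside it, and with only two examples each of the butyl and ethyl changes, the agreement shows that the steps cannot be told apart, not that either change has a fixed size that would hold on another core.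

In a physicochemical assay (a higher number here means that more compound is needed for the effect, a lower number that less compound is needed), compound 3 gave 286 ug/mL and compound 4 gave 799 ug/mL. The step in the physicochemical assay, a 2.8-fold higher number from compound 3 to compound 4 (0.45 log units; beyond the scatter), is the only one shown for that read-out, which leaves open whether the same change on the shorter chains would behave alike there. Also open, as far as these compounds go, is how a longer chain than that of compound 4, a branched chain, or a chain ending in an amine or a carboxylic acid would fare in the MCF7 assay.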